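The source may report more compounds than this note shows. Statements on the series, on what has been measured and on what is new or still open speak of the compounds shown alone.

Compound 1 `CCOc1cc(C2CCN(C)CC2)ccc1Nc1ncc2c(n1)N(Cc1sccc1C)[C@H](CC)C(=O)N2C`: 68 nM
Compound 2 `CCOc1cc(C2CCN(C)CC2)ccc1Nc1ncc2c(n1)N(Cc1cccc(Br)c1)[C@H](CC)C(=O)N2C`: 540 nM
Compound 3 `CCOc1cc(C2CCN(C)CC2)ccc1Nc1ncc2c(n1)N(Cc1cccc(Cl)c1)[C@H](CC)C(=O)N2C`: 540 nM

All three numbers come from an assay on isolated protein for inhibition of serine/threonine-protein kinase PLK1 (Homo sapiens), read by Z'-LYTE, with a stated time of 60 min; on this read-out lower numbers stand for stronger inhibition and higher numbers for weaker inhibition. Compound 1 stands lowest of the three; the other two sit well away from it, as the steps of a 7.9-fold higher number from compound 1 to compound 2 (0.90 log units; beyond the scatter) and a 7.9-fold higher number from compound 1 to compound 3 (0.90 log units; beyond the scatter) show. Between compound 2 and compound 3 there is no change at the digits printed from compound 2 to compound 3 (within the scatter), so the bromo and chloro analogues read as one and the same in this assay.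

Compound 4 `CCOc1cc(C2CCN(C)CC2)ccc1Nc1ncc2c(n1)N(Cc1cccc(C#N)c1)[C@H](CC)C(=O)N2C` is not yet measured. Its change from compound 1 is 3-cyanophenyl in place of 3-methylthiophen-2-yl on a saturated chain carbon bound to a nitrogen on an aromatic ring in a ring. Both measured steps bear on it: each replaces the same group on the saturated chain carbon bound to a nitrogen on an aromatic ring in a ring with a substituted phenyl, and each gave the same modest rise. Within the data shown here, the nitrile is a third substituent of that kind on the phenyl, and nothing among the measured compounds separates it from the halogens, so a rise of the same order is expected in this assay. The expected step is a 7.4-fold higher number from compound 1 to compound 4 (0.87 log units; beyond the scatter), and compound 4 is estimated at 500 nM with a range of 200 nM to 1300 nM.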

Compound 4, half-maximal inhibitory concentration: 1800 nM
Beside the measured number, compound 4's estimate is 3.6-fold (0.56 log units) below it, and the stated range ends below it.
By their numbers in this assay, from the lowest: compound 1; then compounds 2 and 3 (each within the scatter of the next); then compound 4.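

In this assay, the substituent on the phenyl at this place matters: a 3.3-fold higher number from compound 3 to compound 4 (0.52 log units; beyond the scatter) and a 3.3-fold higher number from compound 2 to compound 4 (0.52 log units; beyond the scatter) both lie beyond the scatter, whereas the bromo and chloro analogues could not be told apart. The change from (3-methylthiophen-2-yl)methyl to 3-cyanobenzyl gives a 26-fold higher number from compound 1 to compound 4 (1.42 log units; beyond the scatter), a large step where the halogen replacements gave modest ones, so the size of the step is not set by the phenyl alone. No available evidence accounts for the nitrile reading apart from the halogens.

Still open, going by these compounds, is how an unsubstituted phenyl or a 3-methylphenyl would read at this place, which would separate the contribution of the ring from that of its methyl. On these data alone, it is also open whether an amine or a carboxylic acid on the phenyl would follow the nitrile or the halogens.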